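Fluoro in place of hydrogen on compound 1

This account rests on a few compounds, and the source may have more. Where it says the series, first, only, none or still open, it means among the compounds named here.

Among the compounds with values here, in a functional assay on the whole organism with Rattus norvegicus as the target (on this read-out higher numbers stand for an effect only at larger amounts of compound and lower numbers for an effect already at smaller amounts), compound 1 (`O=C(O)c1ccc(-c2ccccc2)cc1O`) gives 150 mg/kg, the higher of the two numbers so far, and compound 2 (`Cc1cc(-c2ccc(F)cc2)cc(C(=O)O)c1O`) gives 60 mg/kg, a gap beyond the scatter. Compound 3 (`O=C(O)c1ccc(-c2ccc(F)cc2)cc1O`) has fluoro in place of hydrogen on an aromatic carbon, para to a large group (fluoro in place of hydrogen on an aromatic carbon). Within the data shown here, no measured step isolates this change. Among the measured compounds shown here, the only guide is compound 2 at 60 mg/kg, which carries fluoro but also differs from compound 1 elsewhere. The expected step of a 1.4-fold lower number from compound 1 to compound 3 (0.15 log units; within the scatter) is small, toward a lower number, and may stay within the scatter. For compound 3 the estimated value is 105 mg/kg, with an expected range of 50 mg/kg to 220 mg/kg.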

Compound 3, dose for half-maximal effect: 400 mg/kg
The estimate for compound 3 lay 3.8-fold (0.58 log units) below the measured number; the whole stated range lies below it.
By their numbers in this assay, from the lowest: compound 2; then compound 1; then compound 3.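

In this assay, fluoro in place of hydrogen on an aromatic carbon, para to a large group, gives a 2.7-fold higher number from compound 1 to compound 3 (0.43 log units; beyond the scatter), so on the core of compound 1 this single change raises the number rather than lowering it. Within the data shown here, this is the first isolated reading of the change. Compound 2 could not give this reading; it differs elsewhere as well. No measurement shown accounts for the direction of this step.

From the compounds shown here alone, whether a chloro or methoxy group at this place would move the number the same way stays open, as does whether fluoro has the same effect on the core of compound 2.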